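Chain-end substitution from compound 1 to compound 4

The source may hold more compounds than are shown below. What is called first, only, known or untested is meant among the compounds shown, and "the series" means these compounds.

Compound 1 `CC/N=C(\S)NCCCCCn1nc(-c2ccccc2)ccc1=O` gives 51.8 mg/kg in a functional assay on the whole organism (stomach) with Rattus norvegicus as the target (on this read-out lower numbers stand for an effect already at smaller amounts and higher numbers for an effect only at larger amounts of compound), the lowest of the two numbers in hand. Compound 3 `N#CNC(=N)NCCCCn1nc(-c2ccccc2)ccc1=O` gives 77.2 mg/kg in this assay, and a 1.5-fold higher number from compound 1 to compound 3 (0.17 log units; within the scatter). Compound 2 `CC(C)(C)/N=C(\S)NCCCCn1nc(-c2ccccc2)ccc1=O` reaches only the limit of this assay, > 100 mg/kg. That matches (the limit of > 100 mg/kg in this assay, at which 1 of the 3 values shown sits). Accordingly an at least 1.9-fold higher number from compound 1 to compound 2 (0.28 log units; that floor lies within the scatter). Compound 4 `CN(C)/C(=N/CCCCCCn1nc(-c2ccccc2)ccc1=O)NC#N` differs from compound 1 as follows: a group of 9 heavy atoms (5 carbon, 4 nitrogen; no ring) in place of a group of 6 heavy atoms (3 carbon, 2 nitrogen, 1 sulfur; no ring), on a saturated chain carbon, five bonds along the chain from an aromatic nitrogen. Both measured steps away from compound 1 run the same way, one within the scatter, one a floor, and the change to compound 4 shares features with the groups entering in compound 3 and compound 2. A modest upward step is therefore expected, a 1.5-fold higher number from compound 1 to compound 4 (0.19 log units; within the scatter), with a real chance of only a limit. Compound 4 is estimated at 80 mg/kg, between 40 mg/kg and 160 mg/kg.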

Compound 4, dose for half-maximal effect: 93.1 mg/kg
Estimate against measurement, compound 4: 1.2-fold (0.07 log units) below; low and high end bracket the measured number.
By their numbers in this assay, from the lowest: compounds 1, 3 and 4 (each within the scatter of the next). At a limit, above all of these: compound 2.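

The exchange at the saturated chain carbon, five bonds along the chain from an aromatic nitrogen, gives a 1.8-fold higher number from compound 1 to compound 4 (0.25 log units; within the scatter), so the larger group with the triple bond does not separate from the group it replaces in this assay. Compound 4 gives a number rather than a limit. Compound 2 alone stays at a limit: the limit of > 100 mg/kg in this assay, at which 1 of the 4 values shown sits.

From the compounds shown here alone, whether the same group on the chain of compound 1 would read alike remains open. So does how an amine or a carboxylic acid at this chain end would read in this assay.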